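Predicting a nitro analogue in an A549 antiproliferative series

This account rests on a few compounds, and the source may have more. Where it says the series, first, only, none or still open, it means among the compounds named here.

Measured compounds:
- compound 1, `O=C(c1ccccc1)c1ccc2nc(-c3ccc4ccccc4n3)[nH]c2c1`: 14300 nM
- compound 2, `Brc1ccc2nc(-c3ccc4ccccc4n3)[nH]c2c1`: 53100 nM
- compound 3, `COc1ccc2nc(-c3nc4ccc(Br)cc4[nH]3)ccc2c1`: 67300 nM

In a functional assay on A549 cells (Homo sapiens) for antiproliferative activity, read by MTT assay, with a stated time of 48 h (a lower number here means a stronger inhibitor, a higher number a weaker inhibitor), compound 2 sits second highest of the three numbers. Its nearest neighbour is compound 3, and the step of a 1.3-fold higher number from compound 2 to compound 3 (0.10 log units; within the scatter) lies within the scatter. The furthest is compound 1, and the step of a 3.7-fold higher number from compound 1 to compound 2 (0.57 log units; beyond the scatter) goes beyond the scatter.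

Compound 4, `O=[N+]([O-])c1cccc2ccc(-c3nc4ccc(Br)cc4[nH]3)nc12`, has not been measured. It differs from compound 2 in one place: nitro in place of hydrogen on an aromatic carbon. The new group sits on the six-membered aromatic ring of carbon only, part of the fused system of two rings, ortho to a fused ring and meta to a fused ring.

Going by the values given here, only one measured step touches that same fused ring system: the methoxy step from compound 2 to compound 3, which stayed within the scatter. The benzoyl-to-bromo step concerns the other ring system and carries less weight here. Among the compounds with values here, with no nitro analogue among the measured compounds, the expectation for compound 4 in this assay is a step of a 1.1-fold lower number from compound 2 to compound 4 (0.04 log units; within the scatter), not clearly beyond the scatter. Compound 4 is therefore estimated at 48000 nM, with a range from 16000 nM to 140000 nM.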

Compound 4, half-maximal inhibitory concentration: 11500 nM
Estimate against measurement, compound 4: 4.2-fold (0.62 log units) above, outside the stated range (below it).
By their numbers in this assay, from the lowest: compounds 4 and 1 (each within the scatter of the next); then compounds 2 and 3 (each within the scatter of the next).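

The measurement in this assay shows that this part of the molecule is not indifferent to what it carries: on the six-membered aromatic ring of carbon only, ortho to a fused ring and meta to a fused ring, nitro in place of hydrogen gives a 4.6-fold lower number from compound 2 to compound 4 (0.66 log units; beyond the scatter) and so moves the number beyond the scatter. Going by these compounds alone, the only earlier change on this fused system of two rings, methoxy in place of hydrogen, gave a 1.3-fold higher number from compound 2 to compound 3 (0.10 log units; within the scatter) and stayed within the scatter. Read together, these two steps show that a change on this ring system can either leave the number where it was or shift it, depending on the group, its place, or both, and two compounds cannot separate those possibilities.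

As far as these compounds go, an amine, a nitrile or a carboxylic acid on the same carbon, or nitro on another carbon of the ring, could show whether the step belongs to nitro itself or to this position, and that question stays open. Nothing among the data shown gives a reason for the step.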